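Moving the Ring Nitrogen in a Vinyl Sulfone Series

The source may hold more compounds than are shown below. What is called first, only, known or untested is meant among the compounds shown, and "the series" means these compounds.

Compound 1 `O=S(=O)(/C=C/c1ccccn1)c1cccc(F)c1` is the reference point. For the measured compounds named here, in an assay on U2OS cells for activation of nuclear factor erythroid 2-related factor 2 (Homo sapiens), read by beta-arrestin recruitment, with a stated time of 6 h (a lower number here means that less compound is needed, a higher number that more compound is needed for the effect), compound 1 gives 1680 nM, the highest of the three numbers measured so far. Compound 2 `O=S(=O)(/C=C/c1ncccc1F)c1cccc(F)c1` gives 474 nM, and the step of a 3.5-fold lower number from compound 1 to compound 2 (0.55 log units; beyond the scatter) comes from fluoro in place of hydrogen on an aromatic carbon. Compound 3 `O=S(=O)(/C=C/c1ccccn1)c1cccc(Cl)c1` gives 1430 nM, and the step of a 1.2-fold lower number from compound 1 to compound 3 (0.07 log units; within the scatter) comes from chloro in place of fluoro on an aromatic carbon. Compound 4 `O=S(=O)(/C=C/c1ccncc1)c1cccc(F)c1` is not yet measured; it differs from compound 1 in one place: pyridin-4-yl in place of pyridin-2-yl on a double-bonded chain carbon bound to a double-bonded chain carbon.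

Neither measured step bears directly on this change. Going by the values given here, the step from compound 1 to compound 2 adds a halogen, and the step from compound 1 to compound 3 exchanges one halogen for another; neither moves the ring nitrogen, so no measured precedent tells the direction. The expected step is therefore a 1.2-fold higher number from compound 1 to compound 4 (0.08 log units; within the scatter), no further than the scatter in either direction. Compound 4 is thus estimated at 2000 nM, with a range from 600 nM to 7000 nM.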

Compound 4, half-maximal effective concentration: 950 nM
Compound 4: the middle estimate sits 2.1-fold (0.32 log units) above what was measured; low and high end bracket the measured number.
By their numbers in this assay, from the lowest: compounds 2, 4, 3 and 1 (each within the scatter of the next, the first and the last beyond it).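

In this assay, pyridin-4-yl in place of pyridin-2-yl gives a 1.8-fold lower number from compound 1 to compound 4 (0.25 log units; within the scatter), the first step shown that moves the ring nitrogen rather than changing a halogen. At this place on the double-bonded chain, then, the two pyridine attachments are not separated by this measurement, even though the atoms and the counted features of the two groups are the same. No measured evidence bears on why the two groups fall so close together.

The compounds shown leave open whether pyridin-3-yl or a plain phenyl ring at this place would also stay within the scatter of compound 1. They also leave open whether the fluoro substitution that separates compound 2 from compound 1 would give a step of similar size on the pyridin-4-yl ring of compound 4.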